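Swapping one aromatic ring: what the growth read-out may show

This account rests on a few compounds, and the source may have more. Where it says the series, first, only, none or still open, it means among the compounds named here.

Measured so far:
compound 1 `COc1ccccc1/C=C(/SCc1ccc(C)cc1)C(=O)c1ccc(Cl)cc1`: 10000 nM
compound 2 `Cc1ccc(CS/C(=C/c2ccccc2Br)C(=O)c2ccc(Cl)cc2)cc1`: 10000 nM

Both compounds were tested in a functional assay on DU-145 cells (Homo sapiens) for inhibition, read by trypan blue exclusion, with a stated time of 96 h; on this read-out lower numbers stand for stronger inhibition of growth and higher numbers for weaker inhibition of growth. Compound 1 gives 10000 nM there, and compound 2 gives 10000 nM. Among the measured compounds shown here, the single measured step, no change at the digits printed from compound 1 to compound 2 (within the scatter), is flat, so compound 2 stands level with compound 1 on this read-out and no order can be read between the two.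

Compound 3 `Cc1ccc(CS/C(=C/c2ccc(Cl)cc2)C(=O)c2ccc(Cl)cc2)cc1` differs from compound 2 by 4-chlorophenyl in place of 2-bromophenyl on a double-bonded chain carbon bound to a double-bonded chain carbon. For the measured compounds named here, the only step that bears on this change is the one just described: it, too, altered the ring on the double-bonded chain carbon, though by exchanging a substituent rather than moving it, and it came out as no change at the digits printed from compound 1 to compound 2 (within the scatter). Nothing measured has shifted this aromatic ring itself, so the expectation rests on that one flat step.

Compound 3 is therefore expected to give 10000 nM, with a likely range from 4000 nM to 25000 nM. The expected step of no change at the digits printed from compound 2 to compound 3 (within the scatter) is estimated to lie within the usual scatter.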

Compound 3, concentration for 50% growth inhibition: 10000 nM
Compound 3: middle estimate and measured number agree at the digits printed; the measured number falls inside the stated range.
By their numbers in this assay, from the lowest: compounds 1, 2 and 3 (each within the scatter of the next).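

In this assay, 4-chlorophenyl in place of 2-bromophenyl on a double-bonded chain carbon bound to a double-bonded chain carbon gives no change at the digits printed from compound 2 to compound 3 (within the scatter), and 4-chlorophenyl in place of 2-methoxyphenyl at that same place gives no change at the digits printed from compound 1 to compound 3 (within the scatter). The earlier pair compared only 2-methoxyphenyl and 2-bromophenyl, so this result adds something new: 4-chlorophenyl, a ring with a different halogen, also stands level with both of them, and the three rings cannot be told apart on this read-out. No outside measurement is available to explain this flat result.

Among the compounds shown here, still open is whether an amine or a carboxylic acid on this ring, or a longer chain in its place, would give a number that differs from the one for compound 3, 10000 nM. The rest of the shared core is identical in all three compounds, so these results say nothing about how changes elsewhere in the structure would read in this assay.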